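Changing the Aryl Group on the Ring Nitrogen

The compounds below may be only part of what the source reports. "The series", "measured", "known", "first", "only" and "open" are said of these compounds alone.

Three compounds share one core and differ only in the aromatic group attached to an aromatic nitrogen of that core. Compound 1 `CC(C)c1ccc(-n2nc(-c3ccc(C(F)(F)F)cc3O)nc2-c2ccccc2O)cc1` carries a 4-isopropylphenyl group there; in a functional assay on PC-12 cells (Rattus norvegicus) for cytotoxicity, read by MTT assay, with stated times of 2 h and 24 h, tested at 5 uM (on this read-out higher numbers stand for a stronger effect at the one concentration tested and lower numbers for a weaker effect), compound 1 gives 100%. Compound 2 `Oc1cc(C(F)(F)F)ccc1-c1nc(-c2ccccc2O)n(-c2ccccc2Cl)n1` has a 2-chlorophenyl group in that place, and in this assay compound 2 gives 90.6%. Compound 3 `Oc1cc(C(F)(F)F)ccc1-c1nc(-c2ccccc2O)n(-c2cccc(C(F)(F)F)c2)n1` bears a 3-(trifluoromethyl)phenyl group, and in this assay compound 3 gives 92.2%. Among these three numbers compound 3 stands second highest, yet the step of a number 1.6 percentage points higher from compound 2 to compound 3 (within the scatter) and the step of a number 7.8 percentage points lower from compound 1 to compound 3 (within the scatter) are both within the scatter, as is a number 9.4 percentage points lower from compound 1 to compound 2 (within the scatter), so the three compounds cannot be told apart on these data.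

Compound 4 `Oc1cc(C(F)(F)F)ccc1-c1nc(-c2ccccc2O)n(-c2cc(F)cc(F)c2)n1` is the next member: 3,5-difluorophenyl in place of 3-(trifluoromethyl)phenyl on an aromatic nitrogen. All three measured steps exchange the group on the same aromatic nitrogen, and none of them shifted the read-out beyond the scatter. A swap of the same kind is therefore expected to leave the read-out essentially where it is, with the expected step of a number 0.2 percentage points lower from compound 3 to compound 4 (within the scatter) lying within the scatter. On that basis compound 4 is estimated to give 92% in this assay, with an expected range from 80% to 100%.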

Compound 4, a percentage reported as activity, at one concentration (the size of the read-out at that concentration, not a potency): 100%
For compound 4 the middle estimate is 8 percentage points below the measured one; measured number inside the range.
By their numbers in this assay, from the lowest: compounds 2, 3, 1 and 4 (each within the scatter of the next).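

The change to 3,5-difluorophenyl gives a number 7.8 percentage points higher from compound 3 to compound 4 (within the scatter) in this assay, while the comparisons with the other two groups give a number 9.4 percentage points higher from compound 2 to compound 4 (within the scatter) and no change at the digits printed from compound 1 to compound 4 (within the scatter), so all four compounds remain indistinguishable on this read-out. Compounds 1, 2 and 3 each carry one substituent on the aryl ring at this aromatic nitrogen, whereas compound 4 carries two, so the lack of a clear shift now extends to a ring substituted at two places. Nothing available here explains why these exchanges leave the read-out within the scatter.

From the compounds shown here alone, all four groups are aryl rings bearing only alkyl or halogen-containing substituents, so it remains open whether an amine or a carboxylic acid on that ring, or a longer alkyl chain in place of the ring, would move the number beyond the scatter. The compounds shown also leave open whether a change elsewhere on the shared core, such as at either hydroxyl group, would matter more than any change at this nitrogen.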